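This account rests on a few compounds, and the source may have more. Where it says the series, first, only, none or still open, it means among the compounds named here.

Measured compounds:
compound 1 `CN(C)CCn1cnnc1-c1cc(Oc2ccc(NC(=O)N/N=C/c3ccc(O)c(Br)c3)cc2F)ccn1` — 5560 nM
compound 2 `CN(C)CCn1cnnc1-c1cc(Oc2ccc(NC(=O)N/N=C/c3ccccc3)cc2F)ccn1` — "not determined" (no result reported)

In an ADME assay on WI-38 cells (Homo sapiens) for cytotoxicity, read by MTT assay, with a stated time of 72 h (a lower number here means a stronger inhibitor, a higher number a weaker inhibitor), compound 1 gives 5560 nM. Among the measured compounds shown here, this is the only number at hand: compound 2, with structure `CN(C)CCn1cnnc1-c1cc(Oc2ccc(NC(=O)N/N=C/c3ccccc3)cc2F)ccn1`, has no result in this assay, so compound 1 cannot be placed against any other compound and simply stands alone. Compound 3, with structure `COc1cc(/C=N/NC(=O)Nc2ccc(Oc3ccnc(-c4nncn4CCN(C)C)c3)c(F)c2)ccc1O`, has not yet been measured. It differs from compound 1 in a single place: methoxy in place of bromo on an aromatic carbon. The shared core is untouched. For the measured compounds named here, no measured pair with a comparable change exists here, so the size of the step can only be judged from the small extent of the change itself. The step of a 1.1-fold higher number from compound 1 to compound 3 (0.03 log units; within the scatter) is expected to stay within the usual scatter, with no clear direction. Compound 3 is therefore expected to give about 6000 nM, within a range from 2500 nM to 15000 nM.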

Compound 3, half-maximal inhibitory concentration: 5320 nM
Estimate against measurement, compound 3: 1.1-fold (0.05 log units) above; the measured number falls inside the stated range.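

In this assay, among the compounds shown here, the change from bromo to methoxy on the aromatic carbon ortho to a hydroxy group gives a 1.0-fold lower number from compound 1 to compound 3 (0.02 log units; within the scatter) and this is the first single change that can be read at all. At this position the two groups cannot be told apart in this assay even though methoxy brings one more heavy atom and a hydrogen-bond acceptor. This rests on one pair and says nothing about other positions.

For the compounds shown here, no step to compound 2 can be read, and whether an amine or a carboxylic acid on this same carbon would also stay within the scatter remains open. Nothing shown here explains why 3-bromo-4-hydroxyphenyl and 4-hydroxy-3-methoxyphenyl read alike.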